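Swapping the thiophene on the carbonyl carbon of compound 2

This account rests on a few compounds, and the source may have more. Where it says the series, first, only, none or still open, it means among the compounds named here.

For the measured compounds named here, in an assay on HEK293-TREx cells for antagonist activity at transient receptor potential cation channel subfamily A member 1 (Homo sapiens), read by calcium flux (on this read-out lower numbers stand for stronger inhibition and higher numbers for weaker inhibition), compound 2 `CCCNc1cc(NC(=O)c2cccs2)cc(C(F)(F)F)c1` gives 390 nM, the lowest of the two numbers so far; compound 1 `O=C(Nc1cc(NCc2cccs2)cc(C(F)(F)F)c1)c1cccs1` gives 2700 nM. Going by the values given here, the only measured step, a 6.9-fold lower number from compound 1 to compound 2 (0.84 log units; beyond the scatter), concerns the saturated chain carbon bound to a nitrogen on an aromatic ring, not the carbonyl carbon. Compound 3 `CCCNc1cc(NC(=O)c2ccc(F)c(F)c2)cc(C(F)(F)F)c1` differs from compound 2 by 3,4-difluorophenyl in place of thiophen-2-yl on a carbonyl carbon. Among the compounds with values here, no measured step touches the carbonyl carbon, so the expectation is no step beyond the scatter. Compound 3 is therefore estimated at 400 nM, between 130 nM and 1300 nM. The expected step is a 1.0-fold higher number from compound 2 to compound 3 (0.01 log units; within the scatter), within the scatter.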

Compound 3, half-maximal inhibitory concentration: 1200 nM
The estimate for compound 3 lay 3.0-fold (0.48 log units) below the measured number; the measured number falls inside the stated range.
By their numbers in this assay, from the lowest: compound 2; then compound 3; then compound 1.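

The carbonyl carbon, which the earlier step did not touch, does respond to its substituent: in this assay, 3,4-difluorophenyl in place of thiophen-2-yl gives a 3.1-fold higher number from compound 2 to compound 3 (0.49 log units; beyond the scatter), a step beyond the scatter. On this read-out, the thiophen-2-yl of compound 2 therefore cannot be exchanged for this six-membered aromatic ring without a change in the number. No evidence bearing on the reason for this step is at hand.

The compounds shown leave open how much of the step goes with the ring and how much with the two fluorines; compound 3 changes both at once. A plain phenyl or a furan-2-yl on the same carbonyl carbon would separate the two.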